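The compounds below may be only part of what the source reports. "The series", "measured", "known", "first", "only" and "open" are said of these compounds alone.

Measured in a functional assay on thoracic aorta (Rattus norvegicus, strain Wistar), with a stated time of 15 min; on this read-out lower numbers stand for an effect already at smaller amounts and higher numbers for an effect only at larger amounts of compound:
compound 1 `CCOc1ccc(F)cc1C(C)NC(=O)N(C)S(=O)(=O)c1ccc(C)cc1` gives 7800 nM
compound 2 `CCOc1ccc(Cl)cc1C(C)NC(=O)N(C)S(=O)(=O)c1ccccc1` gives 10500 nM
compound 3 `CCOc1ccc(F)cc1C(C)NC(=O)N(C)S(=O)(=O)c1ccc(Cl)cc1` gives 24500 nM

Compound 3 has the highest number of the three, with compound 1 and compound 2 both lower by more than the scatter. Still unmeasured is compound 4 `CCOc1ccc(F)cc1C(C)NC(=O)N(C)S(=O)(=O)c1ccccc1`, which has hydrogen in place of chloro on an aromatic carbon, para to a large group, so that 4-chlorophenyl becomes phenyl (hydrogen in place of chloro on an aromatic carbon).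

For the measured compounds named here, one measured step bears on this change. With chloro in place of methyl on an aromatic carbon, the modest step of a 3.1-fold higher number from compound 1 to compound 3 (0.50 log units; beyond the scatter) lies beyond the scatter. Going by the values given here, it replaces methyl rather than hydrogen, so no measured pair compares chloro with hydrogen directly. Compound 2 also carries phenyl, although its core differs from that of compound 4, and compound 2 gives 10500 nM in this series.

A modest move to a lower number is therefore expected in this assay, with the expected step being a 2.5-fold lower number from compound 3 to compound 4 (0.39 log units; beyond the scatter) as an estimate. For compound 4 the estimated value is 10000 nM with an expected range of 4500 nM to 23000 nM in this read-out.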

Compound 4, half-maximal effective concentration: 11500 nM
Estimate against measurement, compound 4: 1.2-fold (0.06 log units) below; the measured number falls inside the stated range.
By their numbers in this assay, from the lowest: compounds 1, 2 and 4 (each within the scatter of the next); then compound 3.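

In this assay, chloro and hydrogen at this place on the aromatic ring can now be compared directly, and going from 4-chlorophenyl to phenyl brings a modest change beyond the scatter (a 2.1-fold lower number from compound 3 to compound 4 (0.33 log units; beyond the scatter)). Compound 3 therefore stands apart from both compound 1 and compound 4, whereas hydrogen and methyl at this place are not distinguished (a 1.5-fold higher number from compound 1 to compound 4 (0.17 log units; within the scatter)). Fluoro in place of chloro on an aromatic carbon also makes no difference beyond the scatter (a 1.1-fold higher number from compound 2 to compound 4 (0.04 log units; within the scatter)), and no measurement available here accounts for any of these steps.

On these data alone, what an amine, a methoxy group or a carboxylic acid would give at this place remains open. Also open, as far as these compounds go, is whether the chloro step carries over to the core of compound 2, or to a core with a longer chain in place of the ethoxy group.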